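A few compounds are considered here, and "the series" means these few. Any claim that something is new, unique, unknown or untested is made for them only; others in the source may bear on it.

Compound 2 `CC(=O)c1c(-c2ccccc2)nn(C)c(=O)c1NCCN1CCN(c2ccccc2F)CC1` in an assay on isolated protein for binding affinity to Alpha-1A adrenergic receptor (Homo sapiens), read by radioligand binding (on this read-out lower numbers stand for stronger inhibition and higher numbers for weaker inhibition), gives 0.32 nM; compound 1 `COc1ccc(Cl)cc1N1CCN(CCNc2c(C(C)=O)c(-c3ccccc3)nn(C)c2=O)CC1` gives 0.28 nM, and the two sit within the scatter of each other. Compound 3 `CC(=O)c1c(-c2ccccc2)nn(C)c(=O)c1NCCN1CCN(c2ccccc2Cl)CC1` carries chloro in place of fluoro on an aromatic carbon. For the measured compounds named here, the one measured step that bears on it, a 1.1-fold higher number from compound 1 to compound 2 (0.06 log units; within the scatter), also exchanged the substituents on that phenyl ring and stayed within the scatter, so no step beyond the scatter is expected here either, in either direction. Compound 3 is therefore estimated at 0.3 nM, within 0.12 nM to 0.8 nM, which would mean a step of a 1.1-fold lower number from compound 2 to compound 3 (0.03 log units; within the scatter).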

Compound 3, inhibition constant: 0.3 nM
The estimate for compound 3 equals the measured number at the digits printed; measured number inside the range.
By their numbers in this assay, from the lowest: compounds 1, 3 and 2 (each within the scatter of the next).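

At this place, on an aromatic carbon ortho to a large group, the fluoro-to-chloro exchange can now be read directly: in this assay it stays flat (a 1.1-fold lower number from compound 2 to compound 3 (0.03 log units; within the scatter)). The 2-chlorophenyl of compound 3 also matches the 5-chloro-2-methoxyphenyl of compound 1 (a 1.1-fold higher number from compound 1 to compound 3 (0.03 log units; within the scatter)), so all three aryl groups shown remain within the scatter. No evidence on hand accounts for this flatness. As far as these compounds go, whether a non-halogen group here, such as an amine or a nitrile, would read the same remains open. So does the effect of a longer chain in place of the present linker.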